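Compound 3: dimethoxy groups on the acetyl series phenyl

The compounds below may be only part of what the source reports. "The series", "measured", "known", "first", "only" and "open" are said of these compounds alone.

- compound 1 `COc1ccc(-c2c[nH]c(=O)n2-c2cc(OC)c(OC)c(OC)c2)cc1[N+](=O)[O-]`: > 50000 nM
- compound 2 `COc1cc(-n2c(-c3ccccc3)cn(C(C)=O)c2=O)cc(OC)c1OC`: 9600 nM

In a functional assay on K-562R cells (Homo sapiens) for cytotoxicity, read by MTT assay, with a stated time of 48 h (a higher number here means a weaker inhibitor, a lower number a stronger inhibitor), the value of compound 1 (> 50000 nM) is a limit and not a number. Within the data shown here, compound 2 (9600 nM) holds the only actual number so far. Compound 3 `COc1ccc(-c2cn(C(C)=O)c(=O)n2-c2cc(OC)c(OC)c(OC)c2)cc1OC` is not yet measured and departs from compound 2 by 3,4-dimethoxyphenyl in place of phenyl on an aromatic carbon, with 3,4-dimethoxyphenyl in place of phenyl on an aromatic carbon. Among the measured compounds shown here, no measured pair isolates this change. The expectation rests on compound 2 (9600 nM) and foresees a modest move in this assay toward stronger inhibition, little beyond the scatter. The expected size is a 1.4-fold lower number from compound 2 to compound 3 (0.14 log units; within the scatter) in this estimate. Compound 3 is expected at 7000 nM (2000 nM to 25000 nM) as an estimate.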

Compound 3, half-maximal inhibitory concentration: > 50000 nM
Compound 3: no number, only a limit; the forecaster's own chance of this, stated with the estimate: 12%; at least 7.1-fold (0.85 log units) between middle value and limit.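

Among these compounds, on the acetyl series, this is the first measured change at this position: in this assay, 3,4-dimethoxyphenyl in place of phenyl gives an at least 5.2-fold higher number from compound 2 to compound 3 (0.71 log units; beyond the scatter). Compound 3 gives > 50000 nM, which is a limit and not a number. The step therefore fixes only a minimum size, and phenyl remains the only group here at this position with a measured number: the limit of > 50000 nM in this assay, at which 2 of the 3 values shown sit.

Which of the two methoxy groups carries the step stays open. So does whether a single methoxy, a hydroxyl or an amine on this phenyl would keep a measurable number.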